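The source may report more compounds than this note shows. Statements on the series, on what has been measured and on what is new or still open speak of the compounds shown alone.

Compound 1 `COc1cc(-c2cc(/C=C/C(=O)c3ccc(Cl)c(Cl)c3)[nH]n2)cc(OC)c1OC` and compound 2 `COc1ccc(C(=O)/C=C/c2cc(-c3cc(OC)c(OC)c(OC)c3)n[nH]2)cc1` share a core that carries a carbonyl linked to an aryl ring, and both have been tested in a functional assay on PC-3 cells (Homo sapiens) for cytotoxicity, read by sulforhodamine B assay, with a stated time of 48 h, tested at 100 uM; on this read-out lower numbers stand for a stronger effect and higher numbers for a weaker effect at the one concentration tested. There compound 1 gives 10%, while compound 2 gives 1%. The move a number 9 percentage points lower from compound 1 to compound 2 (within the scatter), so compound 2 stands beside compound 1 within the usual scatter, and neither can be called the stronger of the two.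

Compound 3 `COc1cc(-c2cc(/C=C/C(=O)c3ccc(F)c(F)c3)[nH]n2)cc(OC)c1OC` has not yet been measured in this assay. It differs from compound 2 in one place: 3,4-difluorophenyl in place of 4-methoxyphenyl on a carbonyl carbon. Among the compounds with values here, the only step that bears on this change is the one already seen at the same carbonyl carbon, where swapping 3,4-dichlorophenyl for 4-methoxyphenyl gave a move a number 9 percentage points lower from compound 1 to compound 2 (within the scatter). A halogenated ring at that position in compound 1 and a methoxy-bearing ring in compound 2 thus sat within the scatter of each other, so no step beyond the scatter is expected in this assay for compound 3 either.

Compound 3 is therefore expected to give about 6% in this assay, with a range from 0% to 20%, which would mean a step of a number 5 percentage points higher from compound 2 to compound 3 (within the scatter) from compound 2.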

Compound 3, a percentage reported as activity, at one concentration (the size of the read-out at that concentration, not a potency): -41%
Beside the measured number, compound 3's estimate is 47 percentage points above it; the whole stated range lies above it.
By their numbers in this assay, from the lowest: compound 3; then compounds 2 and 1 (each within the scatter of the next).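

In this assay, within the data shown here, replacing 4-methoxyphenyl with 3,4-difluorophenyl on the carbonyl carbon gives a number 42 percentage points lower from compound 2 to compound 3 (beyond the scatter), so the aryl group at this place can matter far more than the first pair of compounds suggested. Replacing 3,4-dichlorophenyl with 3,4-difluorophenyl gives a number 51 percentage points lower from compound 1 to compound 3 (beyond the scatter), which shows that these two dihalogenated rings do not read alike here, and that a halogenated ring at this place does not by itself set the result; with both steps beyond the scatter, compound 3 is the strongest of the three in this read-out. The data shown offer nothing that accounts for the separation of compound 3 from the other two.

As far as these compounds go, it remains open whether both fluorines are needed, which a ring such as 4-fluorophenyl or plain phenyl could address, and how a ring carrying an amine or a carboxylic acid would behave at the same carbonyl carbon. With readings at one concentration only, the compounds also leave open whether compound 3 would keep its stronger effect over the others at any other concentration.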